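This account rests on a few compounds, and the source may have more. Where it says the series, first, only, none or still open, it means among the compounds named here.

Measured compounds:
Compound 1, `O=C(O)COCCCCC1=CCC[C@@H]1NS(=O)(=O)c1ccc(Cl)c(Cl)c1`: 1900 nM
Compound 2, `Cc1ccc(S(=O)(=O)N[C@H]2CCC=C2CCCCOCC(=O)O)cc1`: 1900 nM

In a functional assay on a cell-free system (plasma) for inhibition of thromboxane A2 receptor (Homo sapiens), read by turbidimetry (on this read-out lower numbers stand for stronger inhibition and higher numbers for weaker inhibition), compound 2 gives 1900 nM, level with compound 1 at the digits shown. The step of no change at the digits printed from compound 1 to compound 2 (within the scatter) came with a 4-methylphenyl in place of 3,4-dichlorophenyl on a sulfonyl sulfur, so swapping the aryl group there left the read-out unchanged. Compound 3, `O=C(O)COCCCCC1=CCC[C@@H]1NS(=O)(=O)c1ccccc1[N+](=O)[O-]`, is not yet measured; it carries 2-nitrophenyl in place of 4-methylphenyl on a sulfonyl sulfur. For the measured compounds named here, only that single step bears on this change, and it lay within the scatter, so the expected step of no change at the digits printed from compound 2 to compound 3 (within the scatter) is none beyond the scatter, in no set direction. The estimate for compound 3 in this assay is 1900 nM, within 600 nM to 6000 nM.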

Compound 3, half-maximal inhibitory concentration: 1900 nM
Compound 3: middle estimate and measured number agree at the digits printed, and the stated range covers the measured number.
By their numbers in this assay, from the lowest: compounds 1, 2 and 3 (each within the scatter of the next).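

In this assay the 2-nitrophenyl group shows no change at the digits printed from compound 2 to compound 3 (within the scatter) and no change at the digits printed from compound 1 to compound 3 (within the scatter) when placed on the same sulfonyl sulfur. This extends the flat result to a third aryl group, one that brings nitrogen and oxygen atoms and two hydrogen-bond acceptors, so this position has now held the read-out level across three different substituted phenyl groups. Nothing measured here explains this.

Still open, on these data alone, is whether a small alkyl group such as methyl or a 4-aminophenyl group on that sulfur would move the number. The compounds also leave open what an amide in place of the carboxylic acid, or a longer chain, would do.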